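A few compounds are considered here, and "the series" means these few. Any claim that something is new, unique, unknown or untested is made for them only; others in the source may bear on it.

Compound 1 `CC(C)C1CC(=O)c2s/c(=N/c3ccc(F)cc3)oc2C1`: 3650 nM in a functional assay on NCI-H23 cells (Homo sapiens) for antiproliferative activity, read by sulforhodamine B assay; on this read-out lower numbers stand for stronger inhibition of growth and higher numbers for weaker inhibition of growth.
Compound 2 `CC1(C)CC(=O)c2s/c(=N/c3c(Cl)cc(Cl)cc3Cl)oc2C1`: > 30000 nM in this assay, a limit rather than a number (the limit of > 30000 nM in this assay, at which 1 of the 2 values shown sits).

Compound 3 `CC1CC(=O)c2s/c(=N/c3c(Cl)cc(Cl)cc3Cl)oc2C1` differs from compound 2 by hydrogen in place of methyl on a saturated ring carbon. Among the compounds with values here, no measured pair covers this change. For the step from compound 2 to compound 3 in this assay no shift beyond the usual scatter is expected in either direction, so compound 3 is expected to stay at or near the limit. Estimate for compound 3: 30000 nM, range 10000 nM to 100000 nM, step a number no higher from compound 2 to compound 3 (the limit leaves the size open).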

Compound 3, concentration for 50% growth inhibition: > 30000 nM
Compound 3: a limit, no number; the forecaster's own chance of this, stated with the estimate: 70%; the middle value lies on the limit itself.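

Within the data shown here, compound 2 and compound 3 both sit at a limit, so no step between them can be read: the limit of > 30000 nM in this assay, at which 2 of the 3 values shown sit.
On these data alone, what hydrogen in place of methyl on a saturated ring carbon does in this assay remains open for these compounds.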